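Swapping Methyl for Chloro on a Weak Antagonist Series

The compounds below may be only part of what the source reports. "The series", "measured", "known", "first", "only" and "open" are said of these compounds alone.

Of the compounds shown here, two sharing one core have been tested. Compound 1 `O=[N+]([O-])c1ccc2[nH]c(-c3ccc(Cl)cc3Br)nc2c1` and compound 2 `Cc1ccc(-c2nc3cc([N+](=O)[O-])ccc3[nH]2)c(C)c1` were both measured in a functional assay for antagonist activity at Neuropeptides B/W receptor type 1 (Homo sapiens), read by cAMP accumulation; on this read-out lower numbers stand for stronger inhibition and higher numbers for weaker inhibition. In this assay compound 1 gives 1760 nM, and compound 2 gives 1540 nM. These two values sit within the usual scatter of each other, so neither can be called the stronger antagonist on present evidence; both are weak. Among the compounds with values here, no step between two measured compounds exists here, since the pair differs in more than one place.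

Compound 3 `Cc1cc(Cl)ccc1-c1nc2cc([N+](=O)[O-])ccc2[nH]1` has not yet been measured. It differs from compound 2 by chloro in place of methyl on an aromatic carbon, the new chloro sitting meta to a methyl group and para to a large group. Nothing in the two measured values suggests that this swap will move the number beyond the scatter in either direction, so no step beyond the scatter is expected; the step from compound 2 to compound 3 is estimated as a 1.0-fold lower number from compound 2 to compound 3 (0.01 log units; within the scatter). Compound 3 is therefore expected to give about 1500 nM, within a range from 600 nM to 4000 nM.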

Compound 3, half-maximal inhibitory concentration: 2490 nM
The estimate for compound 3 lay 1.7-fold (0.22 log units) below the measured number, and the stated range covers the measured number.
By their numbers in this assay, from the lowest: compounds 2, 1 and 3 (each within the scatter of the next).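

In this assay, chloro in place of methyl on the aromatic carbon para to a large group gives a 1.6-fold higher number from compound 2 to compound 3 (0.21 log units; within the scatter) and so shows no real effect at this position. Methyl in place of bromo on an aromatic carbon gives a 1.4-fold higher number from compound 1 to compound 3 (0.15 log units; within the scatter) and is likewise too small a step to rank the two compounds, so these two single swaps among small groups leave the series as weak antagonists. Nothing available explains why the numbers fall where they do.

As far as these compounds go, it remains open whether any group at this position can move the number beyond the scatter in either direction. An amine, a carboxylic acid or a longer chain such as propyl in place of the chloro of compound 3 would differ far more from methyl and chloro than these two do from each other.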